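The compounds below may be only part of what the source reports. "The series", "measured", "known", "first", "only" and "open" are said of these compounds alone.

Compounds with a result so far:
- compound 2 `O=C(/C=C(O)/C=C/c1ccc(O)c(O)c1)c1ccccc1O`: 14300 nM
- compound 1 `O=C(/C=C(O)/C=C/c1cccc(O)c1)c1ccccc1O`: "not determined" (no result reported)
- compound 3 `O=C1/C(=C/c2ccccc2)CCC/C1=C\c1cccc(Cl)c1Cl`: "not determined" (no result reported)

Working notes on the series. Three compounds have been taken into an assay on isolated protein for inhibition of Alpha glucosidase (Homo sapiens), with stated times of 5 min and 15 min; on this read-out lower numbers stand for stronger inhibition and higher numbers for weaker inhibition. Among the measured compounds shown here, compound 2 `O=C(/C=C(O)/C=C/c1ccc(O)c(O)c1)c1ccccc1O` is the only one with a number: in this assay compound 2 gives 14300 nM. Compound 1 `O=C(/C=C(O)/C=C/c1cccc(O)c1)c1ccccc1O` and compound 3 `O=C1/C(=C/c2ccccc2)CCC/C1=C\c1cccc(Cl)c1Cl` carry no result in this assay, so compound 2 stands alone and its value cannot be set in order against anything else in the set. For the measured compounds named here, no pair of measured compounds differs in a single place, and so no measured step is available from which the weight of a single change could be read.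

The next compound, compound 4 `O=C(/C=C(O)/C=C/c1ccc(O)c(O)c1)c1cc(Cl)ccc1O`, is compound 2 with one alteration: chloro in place of hydrogen on an aromatic carbon. Nothing measured here speaks to the effect of such a change. The expectation for the step from compound 2 to compound 4 is therefore a small one, of a size that stays within the usual scatter of this assay rather than beyond it, leaning if anything toward a lower number; this is the step the estimate a 1.4-fold lower number from compound 2 to compound 4 (0.16 log units; within the scatter) expresses. On that basis compound 4 is expected to give about 10000 nM in this assay, with a range from 3500 nM to 30000 nM.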

Compound 4, half-maximal inhibitory concentration: 15100 nM
Compound 4: middle estimate off by 1.5-fold (0.18 log units), on the low side; measured number inside the range.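

In this assay, among the compounds shown here, the single measured step, a 1.1-fold higher number from compound 2 to compound 4 (0.02 log units; within the scatter), lies within the scatter. Chloro in place of hydrogen on this aromatic carbon, para to a hydroxy group and meta to a large group, therefore leaves the read-out indistinguishable from that of the parent, something compound 2 alone could not show while it was the only compound with a number. No measurement at hand bears on why this step is so small, and no reason for it can be offered here.

One step at one position says nothing about how far this tolerance extends: a methoxy group, a carboxylic acid or an amine in place of the chloro could give a quite different number in this assay. From the compounds shown here alone, it also remains open whether chloro on another aromatic carbon elsewhere on the core would stay as close to compound 2 as compound 4 does.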